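This account rests on a few compounds, and the source may have more. Where it says the series, first, only, none or still open, it means among the compounds named here.

- compound 1 `O=C(Nc1ccc2[nH]ccc2n1)[C@H]1CCCN1C(=O)C1(c2cccc(Cl)c2)CCCC1`: 5.9
- compound 2 `O=C(Nc1ccc2[nH]ncc2n1)[C@H]1CCCN1C(=O)C1(c2ccc(F)cc2)CCC1`: 4.1
- compound 3 `O=C(Nc1ccc2[nH]ncc2n1)[C@H]1COCCN1C(=O)C1(c2ccc(Cl)cc2)CC(F)(F)C1`: 4.5

In a physicochemical assay for lipophilicity, at pH 7.4 (on this read-out lower numbers stand for lower lipophilicity and higher numbers for higher lipophilicity), compound 1 stands highest of the three at 5.9. Its gaps to the other two are beyond the scatter: compound 3 gives 4.5 and compound 2 gives 4.1.

Compound 4 `O=C(Nc1ccc2[nH]nnc2c1)[C@H]1CCCN1C(=O)C1(c2cccc(Cl)c2)CCCC1` keeps the rest of compound 1 and changes only the group on an amide-type nitrogen: a group of 9 heavy atoms (6 carbon, 3 nitrogen; one five-membered aromatic ring with 3 hetero atoms, one six-membered aromatic ring of carbon only) in place of a group of 9 heavy atoms (7 carbon, 2 nitrogen; one five-membered aromatic ring with 1 hetero atom, one six-membered aromatic ring with 1 hetero atom), on an amide-type nitrogen. The six-membered aromatic ring of the entering group is of carbon only, and its five-membered aromatic ring holds the 3 hetero atoms.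

For the measured compounds named here, no pair of measured compounds differs in one place, so the size of this step is a judgement. Going by the values given here, compound 2 at 4.1 and compound 3 at 4.5 both lie lower than compound 1, but they differ from it in several places and fix no step. A fall beyond the scatter is expected, and the estimated change is a number 1.00 log units lower from compound 1 to compound 4 (beyond the scatter). Compound 4 is estimated at 4.9, with an expected range from 4.1 to 5.6.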

Compound 4, distribution coefficient: 5.2
Compound 4: middle estimate off by 0.30 log units, on the low side, and the stated range covers the measured number.
By their numbers in this assay, from the lowest: compound 2; then compound 3; then compound 4; then compound 1.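

For the compounds shown here, this is the first change that can be read at a single place: on an amide-type nitrogen, with the rest of compound 1 kept, the entering group gives in this assay a number 0.70 log units lower from compound 1 to compound 4 (beyond the scatter). Going by these compounds alone, both groups hold 9 heavy atoms, so the read-out at this position responds to a change in the make-up of the two rings without any change in the heavy-atom count, something the earlier compounds, which differ in several places, could not show. No measurement at hand accounts for the step.

On these data alone, whether the same exchange gives a similar step on the shared core of compound 2 or compound 3 remains open. Also open, as far as these compounds go, is where a plain phenyl or a pyridine ring on this nitrogen would stand.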